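Aryl group change on the amide-type nitrogen

The source may hold more compounds than are shown below. What is called first, only, known or untested is meant among the compounds shown, and "the series" means these compounds.

Compound 3 `Cc1ccc(C)c(NC(=O)Nc2nc(Sc3c[nH]c4ccccc34)cc(N3CCCCC3)n2)c1` gives 25400 nM in a functional assay on A549 cells (Homo sapiens) for inhibition, with a stated time of 72 h; a lower number here means a stronger inhibitor, a higher number a weaker inhibitor. Among the two numbers shown it stands highest; its nearest neighbour is compound 1 `COc1ccc(NC(=O)Nc2nc(Sc3c[nH]c4ccccc34)cc(N3CCCCC3)n2)cc1`, which in this assay gives 13500 nM. Between them, a 1.9-fold higher number from compound 1 to compound 3 (0.27 log units; within the scatter). Compound 2 `O=C(Nc1ccccc1)Nc1nc(Sc2c[nH]c3ccccc23)cc(N2CCN(Cc3ccccc3)CC2)n1` in this assay gives > 50000 nM, which is a limit of the assay and not a number. Among the measured compounds shown here, compound 2 carries the same phenyl group on the amide-type nitrogen as compound 4 but differs elsewhere on the shared core, and no single step links it to compound 3 or compound 4; its value shows only that no number was reached.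

Compound 4 `O=C(Nc1ccccc1)Nc1nc(Sc2c[nH]c3ccccc23)cc(N2CCCCC2)n1` differs from compound 3 as follows: phenyl in place of 2,5-dimethylphenyl on an amide-type nitrogen. For the measured compounds named here, the one measured step that bears on this change is the exchange of the aryl group on the same amide-type nitrogen, from compound 1 to compound 3, which stayed within the scatter. A step of similar size is therefore expected for compound 4, with no direction asserted beyond the scatter; the limit at compound 2 leaves the weaker side open. Compound 4 is expected at 22000 nM, within a range of 8000 nM to 60000 nM. The expected step is a 1.2-fold lower number from compound 3 to compound 4 (0.06 log units; within the scatter).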

Compound 4, half-maximal inhibitory concentration: 33100 nM
Beside the measured number, compound 4's estimate is 1.5-fold (0.18 log units) below it, within the range that was stated.
By their numbers in this assay, from the lowest: compounds 1, 3 and 4 (each within the scatter of the next, the first and the last beyond it). At a limit, above all of these: compound 2.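

In this assay, the exchange of 2,5-dimethylphenyl for phenyl on the amide-type nitrogen gives a 1.3-fold higher number from compound 3 to compound 4 (0.11 log units; within the scatter), so the two methyl groups make no readable difference at this position. Among the compounds shown here, compound 4 also gives the first comparison at this position that clears the scatter, with a 2.5-fold higher number from compound 1 to compound 4 (0.39 log units; beyond the scatter), a modest step that marks hydrogen in place of methoxy on an aromatic carbon. That separation rests on one pair alone, and the data shown hold no measurement that accounts for it.

Open, from the compounds shown here alone, is whether a hydroxyl, an amine or a carboxylic acid in place of the methoxy group on this aryl ring would widen, keep or remove the separation seen between compound 1 and compound 4. Compound 2 gives > 50000 nM, a limit of the assay and not a number, and as it differs from compound 4 elsewhere on the shared core, it leaves open whether the aryl exchange would read the same with another group at that other place.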